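The source may report more compounds than this note shows. Statements on the series, on what has been measured and on what is new or still open speak of the compounds shown alone.

In a functional assay on MCF7 cells (Homo sapiens) for cytotoxicity, read by MTT assay, with a stated time of 48 h (on this read-out lower numbers stand for stronger inhibition and higher numbers for weaker inhibition), three compounds have been measured so far. Compound 2 `C/C(=N/NC(=S)Nc1ccccc1)c1ccccn1`, which has only hydrogen at the position of interest, gives 0.18 nM. Compound 1 `C/C(=N\NC(=S)Nc1ccc(I)cc1)c1ccccn1`, which carries an iodo group, gives 6.61 nM. Compound 3 `C/C(=N/NC(=S)Nc1ccc([N+](=O)[O-])cc1)c1ccccn1`, which carries a nitro group, gives 52 nM, the highest number of the three and so the weakest inhibition measured here.

The next compound is compound 4 `C/C(=N/NC(=S)Nc1ccc(I)cc1)c1ccccn1`, which has iodo in place of nitro on an aromatic carbon, (iodo in place of nitro on an aromatic carbon). For the measured compounds named here, the one measured step that bears directly on this change is a 290-fold higher number from compound 2 to compound 3 (2.46 log units; beyond the scatter), which is large and beyond the scatter. It shows that, between these two compounds, adding a nitro group goes with a much higher number. Removing the nitro group might therefore recover part of that loss, although iodo is a different group from hydrogen. Compound 1 offers a further clue: with iodo it gives 6.61 nM, a number lying between those of the other two compounds. Its structure is not identical to that of compound 4, however, so it is only a rough guide.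

The expected change is towards a lower number, an 8.7-fold lower number from compound 3 to compound 4 (0.94 log units; beyond the scatter). For compound 4, the estimated value is 6 nM, with an expected range of 0.8 nM to 40 nM.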

Compound 4, half-maximal inhibitory concentration: 6.61 nM
Estimate against measurement, compound 4: 1.1-fold (0.04 log units) below; the measured number falls inside the stated range.
By their numbers in this assay, from the lowest: compound 2; then compounds 1 and 4 (each within the scatter of the next); then compound 3.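

In this assay, a 7.9-fold lower number from compound 3 to compound 4 (0.90 log units; beyond the scatter) goes with iodo in place of nitro on this aromatic carbon, while a 37-fold higher number from compound 2 to compound 4 (1.56 log units; beyond the scatter) goes with iodo in place of hydrogen, so iodo recovers only part of what nitro loses. Among these three groups at this place, hydrogen therefore goes with the lowest number, iodo with a middle one and nitro with the highest, and every step among them lies beyond the scatter. For the compounds shown here, the iodo pair shows no change at the digits printed from compound 1 to compound 4 (within the scatter), so drawing the double bond E or Z makes no visible difference in this one pair, the only comparison of its kind here, and it is a clean comparison: the fact that compounds 1 and 4 differ only in the configuration as drawn.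

As far as these compounds go, it remains open whether a methyl, a fluoro, an amine or a carboxylic acid on this aromatic carbon would give a number as low as hydrogen does, or whether every group placed here raises the number. From the compounds shown here alone, it is also open whether the drawn configuration of the double bond would matter as little with nitro or with hydrogen on the ring as it does with iodo.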